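This account rests on a few compounds, and the source may have more. Where it says the series, first, only, none or still open, it means among the compounds named here.

Measured so far in a physicochemical assay for permeability, using PAMPA, at pH 7.4; a higher number here means that the compound crosses the layer faster, a lower number that the compound crosses the layer more slowly:

compound 1 `O=C(NS(=O)(=O)CCNC(=O)C1CC1)c1ccc(Nc2nc(NC3(c4ccc(Cl)cc4)CC3)nc(OCC(F)(F)F)n2)cc1` gives 1 nm/s
compound 2 `O=C(NS(=O)(=O)CCNCc1ccccc1)c1ccc(Nc2nc(NC3(c4ccc(Cl)cc4)CC3)nc(OCC(F)(F)F)n2)cc1` gives 49 nm/s

Compound 2 stands highest of the two numbers in this assay; its nearest neighbour, compound 1, is a long way below it. Among the compounds with values here, the only step within the pair, a 49-fold higher number from compound 1 to compound 2 (1.69 log units; beyond the scatter), is large and runs from a carbonyl-bearing substituent on the amine nitrogen to a benzyl group there.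

Compound 3 `COC(=O)NCCS(=O)(=O)NC(=O)c1ccc(Nc2nc(NC3(c4ccc(Cl)cc4)CC3)nc(OCC(F)(F)F)n2)cc1` is the next compound in the series. The change from compound 2 is methoxycarbonyl in place of benzyl on an amine nitrogen. This runs in the opposite sense to the measured step: the benzyl group leaves and a group carrying a carbonyl, the methoxycarbonyl, enters on the same amine nitrogen. Within the data shown here, the one step that bears on it, a 49-fold higher number from compound 1 to compound 2 (1.69 log units; beyond the scatter), was large, so a large step downward in this assay is expected for compound 3, with the caveat that the entering methoxycarbonyl is not the same as the cyclopropylcarbonyl of compound 1. The expected step is a 25-fold lower number from compound 2 to compound 3 (1.39 log units; beyond the scatter) for compound 3. Compound 3 is therefore estimated at 2 nm/s, within a range of 0.5 nm/s to 8 nm/s.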

Compound 3, apparent permeability: 39 nm/s
Beside the measured number, compound 3's estimate is 20-fold (1.29 log units) below it, and the stated range ends below it.
By their numbers in this assay, from the lowest: compound 1; then compounds 3 and 2 (each within the scatter of the next).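

In this assay, replacing benzyl on the amine nitrogen with methoxycarbonyl gives a 1.3-fold lower number from compound 2 to compound 3 (0.10 log units; within the scatter), so this position accepts the loss of the aromatic ring and the entry of a carbonyl with no change beyond the scatter. Methoxy in place of cyclopropyl on a carbonyl carbon gives a 39-fold higher number from compound 1 to compound 3 (1.59 log units; beyond the scatter), which shows that a carbonyl on this nitrogen does not by itself go with a low number here and that the group attached to that carbonyl carries the large difference among these compounds. No measurement at hand accounts for this difference between the two carbonyl-bearing groups.

The compounds shown leave open whether the low number of compound 1 is particular to cyclopropyl or extends to other carbon groups on the carbonyl, such as methyl, tert-butyl or phenyl. They also leave open how an ethoxy or dimethylamino group on that carbonyl, or a free amine at this nitrogen, would read in this assay.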